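A few compounds are considered here, and "the series" means these few. Any claim that something is new, unique, unknown or untested is made for them only; others in the source may bear on it.

Compound 2 `O=c1ccc2cc(OCc3cn(-c4cccc(CO)c4)nn3)ccc2o1` belongs to a small set of coumarin-linked compounds examined in a functional assay on HL-60 cells (Homo sapiens) for cytotoxicity, read by MTT assay, with a stated time of 48 h; a lower number here means a stronger inhibitor, a higher number a weaker inhibitor. For compound 2 itself no number exists: in this assay compound 2 is recorded as "not determined" (no result reported). The same holds for compound 1 `O=c1ccc2cc(OCc3cc(-c4ccccc4[N+](=O)[O-])no3)ccc2o1`, which in this assay stands at "not determined" (no result reported). Going by the values given here, the only measured member is compound 3 `CC(=O)Nc1ccc(-n2cc(COc3ccc4oc(=O)ccc4c3)nn2)cc1`, which in this assay gives 40400 nM, a weak result. Compound 4 `COc1ccccc1-n1cc(COc2ccc3oc(=O)ccc3c2)nn1` differs from compound 2 by the change (2-methoxyphenyl in place of 3-(hydroxymethyl)phenyl on an aromatic nitrogen), so the shared core remains and only the aryl substituent on the triazole nitrogen is rearranged. Among the compounds with values here, since compound 2 has no number, no step can be computed and nothing is known about whether this change moves potency beyond the scatter in either direction. The expectation for compound 4 therefore rests on compound 3 alone, whose value of 40400 nM suggests that this type of compound is a weak inhibitor in this assay. On that basis compound 4 is expected to give about 35000 nM in this assay, with a likely range from 8000 nM to 150000 nM.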

Compound 4, half-maximal inhibitory concentration: 55200 nM
Estimate against measurement, compound 4: 1.6-fold (0.20 log units) below; low and high end bracket the measured number.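

No step can be read between compound 2 and compound 4 in this assay, where compound 4 gives 55200 nM. The compounds shown leave open whether 2-methoxyphenyl in place of 3-(hydroxymethyl)phenyl changes potency at all. Nothing shown bears on this result.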